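Compound 3: 2-cyanophenyl in place of 3-chlorophenyl

The source may report more compounds than this note shows. Statements on the series, on what has been measured and on what is new or still open speak of the compounds shown alone.

Measured so far in a functional assay on MKN-45 cells (Homo sapiens) for inhibition, read by CCK-8 assay, with a stated time of 24 h; on this read-out lower numbers stand for stronger inhibition and higher numbers for weaker inhibition:
Compound 1 `Cc1ccccc1-n1cc(-c2ccc(/C=C3\C(=O)Nc4ccccc43)cc2)nn1`: 9770 nM
Compound 2 `O=C1Nc2ccccc2/C1=C/c1ccc(-c2cn(-c3cccc(Cl)c3)nn2)cc1`: > 20000 nM, a limit and not a number

Compound 2 has no exact number and stands only at a limit, (the limit of > 20000 nM in this assay, at which 1 of the 2 values shown sits). The next compound, compound 3 `N#Cc1ccccc1-n1cc(-c2ccc(/C=C3\C(=O)Nc4ccccc43)cc2)nn1`, has not yet been measured. It carries 2-cyanophenyl in place of 3-chlorophenyl on an aromatic nitrogen.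

Going by the values given here, only one measured step bears on this change: an at least 2.0-fold higher number from compound 1 to compound 2 (0.31 log units; beyond the scatter), where 3-chlorophenyl replaced 2-methylphenyl on that same aromatic nitrogen. Going by these compounds, this step lies beyond the scatter, but it rests on a single pair, and its true size is unknown. By name, the 2-cyanophenyl of compound 3 is closer to the 2-methylphenyl of compound 1, so compound 1, at 9770 nM, is the better guide. The step expected in this assay is therefore a modest one towards a lower number, estimated as an at least 2.0-fold lower number from compound 2 to compound 3 (0.30 log units; that floor lies within the scatter). For compound 3 the estimated value is 10000 nM, with an expected range of 4000 nM to 20000 nM.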

Compound 3, half-maximal inhibitory concentration: 14600 nM
Compound 3: middle estimate off by 1.5-fold (0.16 log units), on the low side; measured number inside the range.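

In this assay, the new result shows that the group at the 2-position of this phenyl ring can be changed from methyl to cyano with no readable consequence: the swap gives a 1.5-fold higher number from compound 1 to compound 3 (0.17 log units; within the scatter). Going by these compounds, the change from 3-chlorophenyl to 2-cyanophenyl gives an at least 1.3-fold lower number from compound 2 to compound 3 (0.13 log units; that floor lies within the scatter), so even its floor does not establish a real difference, and its true size is unknown. Compound 2 has only a limit and not a number: the limit of > 20000 nM in this assay, at which 1 of the 3 values shown sits.

The compounds shown leave open whether the weaker reading of compound 2 in the first step belongs to the chlorine or to its place on the ring, since that compound differs from the other two in both; a 2-chlorophenyl or a 3-methylphenyl group would separate the two. On these data alone, how far this position tolerates other groups also remains open, for example a plain phenyl, a 2-aminophenyl or a 2-carboxyphenyl group, each of which would test it with something other than the methyl and cyano groups that compound 1 and compound 3 carry.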